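Replacing the 4-methoxyphenyl of compound 1 with methoxy

The source may report more compounds than this note shows. Statements on the series, on what has been measured and on what is new or still open speak of the compounds shown alone.

compound 1 `COc1ccc(-c2ccc(NC3=CC(=O)c4ncncc4C3=O)cc2)cc1` — 2300 nM
compound 2 `CC(=O)c1cccc(NC2=CC(=O)c3ncncc3C2=O)c1` — 900 nM
compound 3 `COc1cccc(NC2=CC(=O)c3ncncc3C2=O)c1` — 600 nM

In a functional assay on PANC-1 cells (Homo sapiens) for cytotoxicity, read by MTT assay, with a stated time of 72 h (on this read-out higher numbers stand for weaker inhibition and lower numbers for stronger inhibition), compound 1 gives the highest number of the three, with compound 2 giving 900 nM and compound 3 giving 600 nM, both lower beyond the scatter. The change to compound 4 `COc1ccc(NC2=CC(=O)c3ncncc3C2=O)cc1` is methoxy in place of 4-methoxyphenyl on an aromatic carbon. For the measured compounds named here, the one measured step, a 1.5-fold lower number from compound 2 to compound 3 (0.18 log units; within the scatter), swaps two groups on a single ring and does not bear directly on removing a ring; no measured pair shows this change. What the data do show is that compounds 2 and 3, which lack the second aromatic ring, give lower numbers than compound 1. Compound 4 is therefore expected to move in the same direction, as a 2.9-fold lower number from compound 1 to compound 4 (0.46 log units; beyond the scatter). The estimate for compound 4 is 800 nM, with a range of 300 nM to 2500 nM.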

Compound 4, half-maximal inhibitory concentration: 800 nM
Beside the measured number, compound 4's estimate shows no gap at the digits printed, within the range that was stated.
By their numbers in this assay, from the lowest: compounds 3, 4 and 2 (each within the scatter of the next); then compound 1.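

In this assay, for the compounds shown here, methoxy in place of 4-methoxyphenyl gives a 2.9-fold lower number from compound 1 to compound 4 (0.46 log units; beyond the scatter), the only measured step here that removes a ring and the only one at this position. The carbon-only aromatic ring that leaves is therefore not needed for activity at this level in this pair. Nothing measured on these compounds accounts for the step.

Open: whether an amine, a carboxylic acid or a longer alkoxy chain at this place would move the number further, and whether the step holds with a group other than methoxy.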